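Chlorophenyl series: from compound 2 to compound 3

The source may hold more compounds than are shown below. What is called first, only, known or untested is meant among the compounds shown, and "the series" means these compounds.

Compound 1 `COc1ccc2[nH]cc(CCCN3CCN(C(=O)CN4CCN(C(=O)c5ccccc5)CC4)CC3)c2c1`: > 200000 nM (a limit of the assay, not a number)
Compound 2 `COc1ccc2[nH]cc(CCCN3CCN(C(=O)CN4CCN(C(=O)c5ccc(Cl)cc5)CC4)CC3)c2c1`: 159000 nM (a measured number)

Going by the values given here, in an ADME assay on SH-SY5Y cells (Homo sapiens) for cytotoxicity, read by MTT assay, with a stated time of 72 h (a lower number here means a stronger inhibitor, a higher number a weaker inhibitor), compound 2 gives 159000 nM as the only actual number so far. Compound 1 has only a limit. Compound 3 `COc1ccc2[nH]cc(CCCN3CCN(C(=O)CN4CCN(C(=O)c5cccc(Cl)c5)CC4)CC3)c2c1` differs from compound 2 by this change: 3-chlorophenyl in place of 4-chlorophenyl on a carbonyl carbon and nothing else. Among the compounds with values here, the one measured step bearing on it is an at least 1.2-fold lower number from compound 1 to compound 2 (0.09 log units; that floor lies within the scatter) for chloro in place of hydrogen, and its floor lies within the scatter. Within the data shown here, no measured step moves the chloro group, so compound 2 at 159000 nM remains the anchor, and no step beyond the scatter is expected in this assay in either direction. The expected 1.1-fold lower number from compound 2 to compound 3 (0.03 log units; within the scatter) stays within the scatter. Compound 3 is estimated at 150000 nM with 80000 nM to 280000 nM as its expected range.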

Compound 3, half-maximal inhibitory concentration: > 200000 nM
Compound 3: a limit, no number (the forecaster's own chance of this, stated with the estimate: 30%); middle value at least 1.3-fold (0.12 log units) away from the limit.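

In this assay, 3-chlorophenyl in place of 4-chlorophenyl on the carbonyl carbon gives an at least 1.2-fold higher number from compound 2 to compound 3 (0.09 log units; that floor lies within the scatter), so moving the chloro group is not shown to change the read-out beyond the scatter. Compound 3 gives a limit and not a number, as does one other compound in the series: the limit of > 200000 nM in this assay, at which 2 of the 3 values shown sit. The step between the two compounds at the limit cannot be read.

Going by these compounds, whether an amine or a carboxylic acid in place of chloro on that aromatic ring would give a measured number in this assay remains open. Also open, on these data alone, is whether such a number would differ from compound 2 beyond the scatter.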